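The source may hold more compounds than are shown below. What is called first, only, known or untested is meant among the compounds shown, and "the series" means these compounds.

Working notes on the series. For the measured compounds named here, in a functional assay on MCF7 cells (Homo sapiens) for inhibition, read by MTT assay (a higher number here means a weaker inhibitor of growth, a lower number a stronger inhibitor of growth), compound 1 `COc1cc2oc(-c3cccc(NC(=O)c4ccc(F)cc4)c3)cc(=O)c2c(OC)c1OC` gives 14700 nM and compound 2 `COc1cc2oc(-c3cccc(NC(=O)c4ccc(C)cc4)c3)cc(=O)c2c(OC)c1OC` gives 8320 nM as the second of only two numbers so far. Going by the values given here, the one measured step is a 1.8-fold lower number from compound 1 to compound 2 (0.25 log units; within the scatter) and it does not separate the pair, so the two stand level.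

Next is compound 3 `COc1ccccc1C(=O)Nc1cccc(-c2cc(=O)c3c(OC)c(OC)c(OC)cc3o2)c1` which is still unmeasured. The change from compound 2 is 2-methoxyphenyl in place of 4-methylphenyl on a carbonyl carbon and reads as 2-methoxyphenyl in place of 4-methylphenyl on a carbonyl carbon, with the shared core untouched. Among the compounds with values here, no measured compound carries the 2-methoxyphenyl group, so no step speaks to it directly. The nearest guide is a 1.8-fold lower number from compound 1 to compound 2 (0.25 log units; within the scatter) which is also an exchange on the aromatic group at the carbonyl carbon and stayed within the scatter. On that thin basis a step beyond the scatter is not expected in this assay and no clear direction is favoured. The expected step is a 1.2-fold higher number from compound 2 to compound 3 (0.08 log units; within the scatter) on this estimate. For compound 3 the estimated value is 10000 nM (expected range 3500 nM to 30000 nM).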

Compound 3, concentration for 50% growth inhibition: 15300 nM
Beside the measured number, compound 3's estimate is 1.5-fold (0.18 log units) below it; measured number inside the range.
By their numbers in this assay, from the lowest: compounds 2, 1 and 3 (each within the scatter of the next).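

In this assay, 2-methoxyphenyl in place of 4-methylphenyl on the carbonyl carbon gives a 1.8-fold higher number from compound 2 to compound 3 (0.26 log units; within the scatter), and the same group in place of 4-fluorophenyl gives a 1.0-fold higher number from compound 1 to compound 3 (0.02 log units; within the scatter). The earlier step compared only 4-fluorophenyl and 4-methylphenyl, whereas 2-methoxyphenyl brings an oxygen and a hydrogen-bond acceptor into the group and still does not separate the three compounds. At this carbonyl carbon, these three aromatic groups therefore stand level, and no order among them can be read from these numbers. No supporting information bears on this result.

On these data alone, it remains open whether a group of another kind on this aromatic ring, such as an amine or a carboxylic acid, or a longer chain in place of the ring, would give a step beyond the scatter. The compounds shown also leave open how 4-methoxyphenyl would compare with 2-methoxyphenyl, and whether any change away from this carbonyl carbon, in the amide or the shared core, would move the number more than these exchanges do.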